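Three thiazolidinone compounds and a fourth awaiting measurement

The source may report more compounds than this note shows. Statements on the series, on what has been measured and on what is new or still open speak of the compounds shown alone.

Compound 1 `O=C1CSC(c2cccc(F)c2)N1CCN1CCCCC1` gives 100% in an ADME assay on Vero cells (Chlorocebus sabaeus) for cytotoxicity, read by neutral red uptake, tested at 12.3 ug/mL; a higher number here means a weaker effect of the compound at the concentration tested, a lower number a stronger effect. Compound 2 `O=C1CSC(c2ccccc2Cl)N1CCN1CCCCC1` gives 100% in this assay. Compound 3 `O=C1CSC(c2ccc([N+](=O)[O-])cc2)N1CCN1CCCCC1` gives 100% in this assay.

On the numbers shown, compound 1 stands level with compounds 2 and 3 in this assay; the step of no change at the digits printed from compound 1 to compound 2 (within the scatter) lies within the scatter, and the values of compound 1 and compound 3 are likewise indistinguishable at the digits printed. None of the three shows any loss of neutral red uptake at the concentration tested.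

Compound 4 `Cc1ccc(C2SCC(=O)N2CCN2CCCCC2)cc1` differs from compound 1 in one place: 4-methylphenyl in place of 3-fluorophenyl on a saturated ring carbon. Going by the values given here, the only measured step that bears on this, the exchange of one aromatic ring for another on the same saturated ring carbon, is no change at the digits printed from compound 1 to compound 2 (within the scatter), which brought no change beyond the scatter. The third compound, with its nitro-bearing ring, also sits at the same level. On that basis no step beyond the scatter is expected in this assay from compound 1 to compound 4, that is no change at the digits printed from compound 1 to compound 4 (within the scatter). Compound 4 is therefore estimated at 100% in this assay, with a range from 88% to 105%.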

Compound 4, a percentage reported as activity, at one concentration (the size of the read-out at that concentration, not a potency): 100%
The estimate for compound 4 equals the measured number at the digits printed; low and high end bracket the measured number.
By their numbers in this assay, from the lowest: compounds 1, 2, 3 and 4 (each within the scatter of the next).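

In this assay, putting 4-methylphenyl in place of 3-fluorophenyl on the saturated ring carbon gives no change at the digits printed from compound 1 to compound 4 (within the scatter), and putting it in place of 2-chlorophenyl gives no change at the digits printed from compound 2 to compound 4 (within the scatter). The earlier compounds shown here carried a fluorine, a chlorine or a nitro group on the aromatic ring at this position, whereas compound 4 shows that a ring bearing only a methyl group stays at the same level, so none of these four aromatic groups separates from the others here. Methyl in place of nitro on an aromatic carbon likewise gives no change at the digits printed from compound 3 to compound 4 (within the scatter), and nothing in the data offers any explanation for this flat result.

All four compounds share one level at the single concentration tested, so the compounds shown do not reveal what, if anything, at this position would lower neutral red uptake. Going by these compounds, an amine or a carboxylic acid on the aromatic ring, or a longer alkyl chain in place of that ring on the saturated ring carbon, remains open, as does the behaviour of this series at higher concentrations.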